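A few compounds are considered here, and "the series" means these few. Any claim that something is new, unique, unknown or untested is made for them only; others in the source may bear on it.

In an assay on HEK293 cells for inhibition of N-acylethanolamine-hydrolyzing acid amidase (Rattus norvegicus), read by LC-MS, with a stated time of 30 min (a lower number here means a stronger inhibitor, a higher number a weaker inhibitor), compound 3 `O=C1OCCN1C(=O)c1ccc(Oc2ccc(O)cc2)cc1` gives > 20000 nM, which is a limit of the assay rather than a measured number. Compound 1 `NC(=O)c1ccc(CCCCCC(=O)N2CCOC2=O)cc1` likewise gives > 20000 nM, again a limit. Compound 2 `Cc1cccc(CCCCCC(=O)N2CCOC2=O)c1`, by contrast, gives 350 nM. Two of the three values shown therefore sit at the limit of > 20000 nM in this assay, at which 2 of the 3 values shown sit, and compound 3 stands among the compounds for which no inhibition could be put into a number in this assay.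

Compound 4 `O=C1OCCN1C(=O)c1ccc(OC2CCC(O)CC2)cc1` differs from compound 3 in one place: 4-hydroxycyclohexyl in place of 4-hydroxyphenyl on an oxygen on an aromatic ring. Among the compounds with values here, no step between two measured compounds is known here, so the size of this change cannot be read from any neighbouring pair, and the direction is open. Compound 4 is expected to stay near the edge of the assay, with an estimated step of a number no higher from compound 3 to compound 4 (the limit leaves the size open) that does not clearly go beyond the scatter. For compound 4 the estimate is 20000 nM, with a range from 3000 nM to 60000 nM.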

Compound 4, half-maximal inhibitory concentration: 210 nM
Compound 4: middle estimate off by 95-fold (1.98 log units), on the high side; the whole stated range lies above it.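

In this assay, replacing 4-hydroxyphenyl with 4-hydroxycyclohexyl on the oxygen gives an at least 95-fold lower number from compound 3 to compound 4 (1.97 log units; beyond the scatter), so a single change at this position separates a compound without a measured number from one with a measured value. The two groups have the same counts of heavy atoms, hydrogen-bond donors and hydrogen-bond acceptors, and the difference printed between them is that one ring is aromatic and the other is non-aromatic. The real size of the step stays unknown, since the value for compound 3 is only a limit: the limit of > 20000 nM in this assay, at which 2 of the 4 values shown sit.

These compounds do not show why the non-aromatic ring gives the stronger result, or whether its hydroxyl group matters. A plain cyclohexyl group, or a cyclohexyl ring carrying an amine or a carboxylic acid in place of the hydroxyl, would help answer the second question.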